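The compounds below may be only part of what the source reports. "The series", "measured", "known", "first", "only" and "open" are said of these compounds alone.

Compound 2 `COc1cc(-c2nnc(SC)n2N2C(=O)c3ccccc3C2=O)cc(OC)c1OC` was examined in a functional assay on MKN-45 cells (Homo sapiens) for cytotoxicity, read by MTT assay, with a stated time of 48 h; a higher number here means a weaker inhibitor, a lower number a stronger inhibitor. In this assay compound 2 gives only > 200000 nM, which is a limit and not a number. Compound 1 `C#CCSc1nnc(-c2cc(OC)c(OC)c(OC)c2)n1N1C(=O)c2ccccc2C1=O`, carrying ethynyl on the saturated chain carbon bound to the sulfur, likewise gives only the limit > 200000 nM in this assay. The step that the two limits leave unreadable from compound 1 to compound 2 thus cannot be read, because both values sit at the limit of > 200000 nM in this assay, at which 2 of the 2 values shown sit. Compound 3 `COc1cc(-c2nnc(SCc3ccccc3)n2N2C(=O)c3ccccc3C2=O)cc(OC)c1OC` carries phenyl in place of hydrogen on a saturated chain carbon bound to a sulfur. Among the measured compounds shown here, no measured step bears on this change, so its size cannot be gauged from two limits. Compound 3 is nonetheless expected near 150000 nM, between 20000 nM and 600000 nM, an estimated step of an at least 1.3-fold lower number from compound 2 to compound 3 (0.12 log units; that floor lies within the scatter).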

Compound 3, half-maximal inhibitory concentration: > 200000 nM
Compound 3 ended at the assay's limit; the forecaster's own chance of this, stated with the estimate: 60%; at least 1.3-fold (0.12 log units) between middle value and limit.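

No step among compound 1, compound 2 and compound 3 can be read, as all three values are limits: the limit of > 200000 nM in this assay, at which 3 of the 3 values shown sit.

The compounds shown leave open whether ethynyl, hydrogen or phenyl on the saturated chain carbon bound to a sulfur makes any difference in this assay.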